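A few compounds are considered here, and "the series" means these few. Any claim that something is new, unique, unknown or untested is made for them only; others in the source may bear on it.

Working notes on the cinnamanilide series.

Compound 1 `NC(=O)c1cc(Cl)ccc1NC(=O)/C=C/c1ccccc1Br` is the reference point. In a functional assay on K562 cells (Homo sapiens) for antiproliferative activity, read by trypan blue exclusion, with a stated time of 48 h, tested at 10 uM (a lower number here means less inhibition of growth, a higher number more inhibition of growth at the concentration tested), compound 1 gives 49%. Compound 2 `NC(=O)c1cc(Cl)ccc1NC(=O)/C=C/c1cccc(Br)c1` carries the ring change 3-bromophenyl in place of 2-bromophenyl on a double-bonded chain carbon bound to a double-bonded chain carbon and in this assay compound 2 gives 27%, so the step is a number 22 percentage points lower from compound 1 to compound 2 (beyond the scatter).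

Compound 3 `NC(=O)c1cc(Br)ccc1NC(=O)/C=C/c1ccccc1Br` shares the cinnamanilide framework with compound 1; the two cores differ only as described by bromo in place of chloro on an aromatic carbon. In this assay compound 3 gives 46.2%, and the step is a number 2.8 percentage points lower from compound 1 to compound 3 (within the scatter), so the two cores behave alike as far as the measured numbers show.

Compound 4 `NC(=O)c1cc(Br)ccc1NC(=O)/C=C/c1cccc(Br)c1` is not yet measured. It relates to compound 3 by 3-bromophenyl in place of 2-bromophenyl on a double-bonded chain carbon bound to a double-bonded chain carbon, which is the same change as that made from compound 1 to compound 2, at the same place. Among the compounds with values here, with the cores behaving alike, that earlier step is the only guide. The step expected in this assay is a number 21.2 percentage points lower from compound 3 to compound 4 (beyond the scatter), resting on the earlier step of a number 22 percentage points lower from compound 1 to compound 2 (beyond the scatter). Compound 4 is therefore estimated at 25%, expected to fall between 13% and 37%.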

Compound 4, percent growth inhibition at one concentration: 45.9%
Compound 4: the middle estimate sits 20.9 percentage points below what was measured; the measured number lies above the stated range.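

In this assay, 3-bromophenyl in place of 2-bromophenyl does not carry the same step from one core to the other; on the bromo core the step is a number 0.3 percentage points lower from compound 3 to compound 4 (within the scatter), which sets it apart from the step on the chloro core: the same change on two cores in this assay, a number 22 percentage points lower (beyond the scatter) from compound 1 to compound 2 and a number 0.3 percentage points lower (within the scatter) from compound 3 to compound 4, 21.7 percentage points apart, beyond the scatter of two such steps

Read along the other edge of the same four compounds, bromo in place of chloro is likewise not a constant step, being a number 18.9 percentage points higher from compound 2 to compound 4 (beyond the scatter) on the 3-bromophenyl side, which differs from its step on the 2-bromophenyl side: the same change on two cores in this assay, a number 2.8 percentage points lower (within the scatter) from compound 1 to compound 3 and a number 18.9 percentage points higher (beyond the scatter) from compound 2 to compound 4, 21.7 percentage points apart, beyond the scatter of two such steps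

Within the data shown here, this shows that, within these four compounds, neither change can be transferred as a fixed increment, but it does not show why, and the whole difference rests on the single low value of compound 2.

The compounds shown leave open whether the same dependence holds with fluoro in place of chloro or with a methoxyphenyl group in place of the bromophenyl groups. They also leave open how a carboxylic acid in place of the carboxamide would behave on either core.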